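Swapping a Phenyl for a Methylsulfonyl Chain

The source may report more compounds than this note shows. Statements on the series, on what has been measured and on what is new or still open speak of the compounds shown alone.

Of the compounds shown here, three have so far been tested in a functional assay on the whole organism with Rattus norvegicus as the target; on this read-out higher numbers stand for an effect only at larger amounts of compound and lower numbers for an effect already at smaller amounts. Compound 1, `Nc1nc2ccc(OCC(F)(F)F)cc2s1`, gives 6.5 mg/kg in this assay. Compound 2, `Nc1nc2ccc(OCC(F)(F)C(F)(F)F)cc2s1`, gives 7.5 mg/kg. Going by the values given here, the one step measured between them, a 1.2-fold higher number from compound 1 to compound 2 (0.06 log units; within the scatter), stays within the scatter, so these two compounds cannot be told apart on this read-out. For compound 3, `N=c1sc2cc(OC(F)(F)F)ccc2n1Cc1ccccc1`, this assay reports only a limit and not a number: compound 3 gives > 10 mg/kg. That limit is the one described as the limit of > 10 mg/kg in this assay, at which 1 of the 3 values shown sits, and it leaves open how far compound 3 lies from the other two.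

Compound 4, `CS(=O)(=O)CCCn1c(=N)sc2cc(OC(F)(F)F)ccc21`, has not yet been measured. It differs from compound 3 by 2-(methylsulfonyl)ethyl in place of phenyl on a saturated chain carbon bound to an aromatic nitrogen. Among the compounds with values here, no measured step concerns this part of the molecule; the only step on record, a 1.2-fold higher number from compound 1 to compound 2 (0.06 log units; within the scatter), changes a different group in a different place and gives no guide here. Starting from a limit, no direction of change can be read from the numbers shown. Compound 4 is therefore expected to give about 10 mg/kg, with a range from 4 mg/kg to 30 mg/kg, and a fair chance that this assay again reports only a limit. The step expected from this estimate is a number no higher from compound 3 to compound 4 (the limit leaves the size open).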

Compound 4, dose for half-maximal effect: 5 mg/kg
Compound 4: the middle estimate sits 2.0-fold (0.30 log units) above what was measured, within the range that was stated.
By their numbers in this assay, from the lowest: compounds 4, 1 and 2 (each within the scatter of the next). At a limit, above all of these: compound 3.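

The earlier compounds shown here gave no step at this position, on a saturated chain carbon bound to an aromatic nitrogen, whereas this assay now shows an at least 2.0-fold lower number from compound 3 to compound 4 (0.30 log units; that floor lies within the scatter). The exchange of phenyl, a ring of carbon only, for 2-(methylsulfonyl)ethyl, which has no ring and brings hydrogen-bond acceptors, therefore does not cost the effect on this read-out, and it gives a readable number where the ring gave only a limit. The true size of the step stays unknown, because one end of it is a limit and not a number: the limit of > 10 mg/kg in this assay, at which 1 of the 4 values shown sits.

This single pair cannot separate the part played by the methylsulfonyl group from the part played by the removal of the ring, and it does not tell how a plain propyl chain, a longer chain ending in methylsulfonyl, or a chain ending in an amine or a carboxylic acid would read in this assay. It also leaves open whether the 3-(methylsulfonyl)propyl chain would give a similar result with a different group in place of the trifluoromethoxy group on the shared core.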